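The source may hold more compounds than are shown below. What is called first, only, known or untested is meant among the compounds shown, and "the series" means these compounds.

Among the compounds with values here, compound 2 `Cc1coc(-c2ccc3c(c2O)CCCC3(C)C)c1CO` is one of three compounds measured in a functional assay on A549 cells (Homo sapiens) for cytotoxicity, read by sulforhodamine B assay, with a stated time of 3 days; a lower number here means that less compound is needed, a higher number that more compound is needed for the effect. In that assay compound 2 gives 24.5 uM, the second highest of the three numbers. Compound 1 `Cc1coc(-c2ccc3c(c2O)CCCC3(C)C)c1C(=O)O` gives 3.3 uM, and compound 3 `Cc1coc(-c2ccc3c(c2O)CCC3)c1C(=O)O` gives 41.5 uM; compound 2 and compound 3 lie within the scatter of each other, while the step of a 7.4-fold higher number from compound 1 to compound 2 (0.87 log units; beyond the scatter) sets compound 2 clearly apart from compound 1. Compound 4 `COc1c(-c2occ(C)c2CO)ccc2c1CCCC2(C)C` has not yet been measured. It differs from compound 2 by methyl in place of hydrogen on an oxygen on an aromatic ring. Within the data shown here, none of the measured steps touches this oxygen: the only measured single-point step, a 7.4-fold higher number from compound 1 to compound 2 (0.87 log units; beyond the scatter), alters the carboxy group instead, and compound 3 differs from compound 1 in the shared core. The measured steps therefore give only a sense of the scale on which numbers move here, not a direction for this change, so the estimate below is wide. The expected step is a 1.6-fold higher number from compound 2 to compound 4 (0.21 log units; within the scatter). Compound 4 is estimated at 40 uM in this assay, within a range of 10 uM to 150 uM.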

Compound 4, concentration for half-maximal effect: 23.3 uM
Beside the measured number, compound 4's estimate is 1.7-fold (0.23 log units) above it, and the stated range covers the measured number.
By their numbers in this assay, from the lowest: compound 1; then compounds 4, 2 and 3 (each within the scatter of the next).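

In this assay, the first change made at the oxygen on the aromatic ring, hydroxy to methoxy, gives a 1.1-fold lower number from compound 2 to compound 4 (0.02 log units; within the scatter). In this pair, then, replacing the hydrogen on that oxygen with a methyl gives a number within the scatter, whereas the earlier change at the other site, hydroxymethyl in place of carboxy, gave a 7.4-fold higher number from compound 1 to compound 2 (0.87 log units; beyond the scatter). Nothing available here explains why the methyl makes so little measurable difference.

As far as these compounds go, this result comes from a single pair carrying the hydroxymethyl group, so it remains open whether methoxy would behave the same way alongside the carboxy group of compound 1. Also open, from the compounds shown here alone, is how a longer chain such as ethyl or a benzyl group on this oxygen, or an amine in its place, would compare.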